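Halogens on the Anilino Ring and Cell Inhibition

A few compounds are considered here, and "the series" means these few. Any claim that something is new, unique, unknown or untested is made for them only; others in the source may bear on it.

Compound 3 `Cc1n[nH]c2ccc(-c3nc4cnc(N5CCN(C)CC5)cn4c3Nc3ccccc3)cc12` stands level with compound 1 `Cc1n[nH]c2ccc(-c3nc4cnc(N5CCN(C)CC5)cn4c3Nc3cccc(Cl)c3)cc12` in a functional assay on MV4-11 cells (Homo sapiens) for inhibition, with a stated time of 120 h, tested at 10 uM (a higher number here means more inhibition at the concentration tested (going by the name of the read-out), a lower number less inhibition), the two together the lowest of the three numbers: compound 3 gives 0% and compound 1 gives 0%. Compound 2 `COc1ccc(Nc2c(-c3ccc4[nH]nc(C)c4c3)nc3cnc(N4CCN(C)CC4)cn23)cc1` gives 3.32%, and the step of a number 3.3 percentage points lower from compound 2 to compound 3 (within the scatter) lies within the scatter. Compound 4 `Cc1n[nH]c2ccc(-c3nc4cnc(N5CCN(C)CC5)cn4c3Nc3ccc(Br)cc3Cl)cc12` differs from compound 3 in one place: 4-bromo-2-chlorophenyl in place of phenyl on a nitrogen on an aromatic ring. Among the measured compounds shown here, two measured steps bear on this, both being changes on the same aromatic ring: no change at the digits printed from compound 1 to compound 3 (within the scatter) and a number 3.3 percentage points higher from compound 1 to compound 2 (within the scatter). Neither moved the number beyond the scatter, so no step beyond the scatter is expected here either. Compound 4 is therefore estimated at 2%, between 0% and 12%, which means an expected step of a number 2 percentage points higher from compound 3 to compound 4 (within the scatter).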

Compound 4, a percentage reported as inhibition, at one concentration (the size of the read-out at that concentration, not a potency): 70.5%
The estimate for compound 4 lay 68.5 percentage points below the measured number; the whole stated range lies below it.
By their numbers in this assay, from the lowest: compounds 1, 3 and 2 (each within the scatter of the next); then compound 4.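

The ring on the nitrogen is not indifferent after all: in this assay, 4-bromo-2-chlorophenyl gives a number 70.5 percentage points higher from compound 3 to compound 4 (beyond the scatter) and a number 70.5 percentage points higher from compound 1 to compound 4 (beyond the scatter) and also a number 67.2 percentage points higher from compound 2 to compound 4 (beyond the scatter) in this one change of ring. A single chloro or methoxy left the number within the scatter of phenyl, whereas this ring with two halogens does not. Nothing measured here accounts for the jump.

Still open, going by these compounds, is whether the bromo alone or the chloro alone would give such a number, or whether both are needed. Also open, on these data alone, is whether a fluoro or an amine in their places would do the same.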